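The source may hold more compounds than are shown below. What is called first, only, known or untested is meant among the compounds shown, and "the series" means these compounds.

Measured compounds:
compound 1, `COc1ccc(F)cc1CNCCCNc1ccnc2cc(Cc3cc(C)cc(C)c3)ccc12` — 23 10^-6 cm/s
compound 2, `COc1ccc(F)cc1CNCCCNc1ccnc2cc(CC(C)C)ccc12` — 23 10^-6 cm/s
compound 3, `COc1ccc(F)cc1CNCCCNc1ccnc2cc(Cc3ccc(C#N)cc3)ccc12` — 23 10^-6 cm/s

In an ADME assay for permeability, using PAMPA, with a stated time of 30 min, at pH 7.4 (a lower number here means that the compound crosses the layer more slowly, a higher number that the compound crosses the layer faster), compound 3 gives 23 10^-6 cm/s and stands level with compounds 1 and 2. The three measured steps, no change at the digits printed from compound 1 to compound 2 (within the scatter), no change at the digits printed from compound 1 to compound 3 (within the scatter) and no change at the digits printed from compound 2 to compound 3 (within the scatter), all exchange the group on the saturated chain carbon and leave the read-out unchanged.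

Compound 4, `COc1ccc(F)cc1CNCCCNc1ccnc2cc(-c3ccc(C(C)(C)C)cc3)ccc12`, differs from compound 3 thus: 4-(tert-butyl)phenyl in place of 4-cyanobenzyl on an aromatic carbon

For the measured compounds named here, this change removes the saturated chain carbon and puts the ring directly on the aromatic carbon; no measured step covers such a change. Going by the values given here, still, every exchange at this position so far left the read-out flat, so for compound 4 the expected step is a 1.0-fold lower number from compound 3 to compound 4 (0.02 log units; within the scatter), none beyond the scatter. Compound 4 is estimated at 22 10^-6 cm/s, expected between 11 10^-6 cm/s and 40 10^-6 cm/s.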

Compound 4, apparent permeability: 237 10^-6 cm/s
Estimate against measurement, compound 4: 11-fold (1.03 log units) below; measured number outside the range, above it.
By their numbers in this assay, from the lowest: compounds 1, 2 and 3 (each within the scatter of the next); then compound 4.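

In this assay this position is not insensitive: 4-(tert-butyl)phenyl on the aromatic carbon gives a 10-fold higher number from compound 3 to compound 4 (1.01 log units; beyond the scatter) and also a 10-fold higher number from compound 2 to compound 4 (1.01 log units; beyond the scatter) and a 10-fold higher number from compound 1 to compound 4 (1.01 log units; beyond the scatter), whereas exchanges on the saturated chain carbon gave no such separation. The step is the same whichever of the three groups leaves, so the nitrile of the 4-cyanobenzyl group is not required to explain it. No available evidence bears on the origin of this step.

Still open, going by these compounds, is whether the lost saturated chain carbon or the tert-butyl group carries the step. A directly attached unsubstituted phenyl or 4-cyanophenyl group would separate the two.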